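3-Chlorophenyl to 4-methoxyphenyl on a shared core

The source may hold more compounds than are shown below. What is called first, only, known or untested is meant among the compounds shown, and "the series" means these compounds.

compound 1 `COc1cccc(/C=C2\CCC/C(=C\c3cccc(Cl)c3)C2=O)c1OC` 12000 nM
compound 2 `COc1cccc(/C=C2\CCC/C(=C\c3cccc(Br)c3)C2=O)c1OC` 11700 nM
compound 3 `COc1ccccc1/C=C1\CCC/C(=C\c2cccc(OC)c2OC)C1=O` 12000 nM

In a functional assay on MCF7 cells (Homo sapiens) for cytotoxicity, read by MTT assay, with a stated time of 72 h (a lower number here means a stronger inhibitor, a higher number a weaker inhibitor), compound 1 gives 12000 nM, and it stands level with the other two compounds, since all three numbers lie within the scatter of one another. The next compound, compound 4 `COc1ccc(/C=C2\CCC/C(=C\c3cccc(OC)c3OC)C2=O)cc1`, has not yet been measured. It is reached from compound 1 by one structural change, with 4-methoxyphenyl in place of 3-chlorophenyl on a double-bonded chain carbon bound to a double-bonded ring carbon.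

For the measured compounds named here, three measured steps bear on this change. The closest is no change at the digits printed from compound 1 to compound 3 (within the scatter), where 2-methoxyphenyl enters at the same place. The step of a 1.0-fold higher number from compound 2 to compound 3 (0.01 log units; within the scatter) makes a similar exchange, and the step of a 1.0-fold lower number from compound 1 to compound 2 (0.01 log units; within the scatter) swaps bromo for chloro on an aromatic carbon. None of these steps leaves the scatter. Going by the values given here, no measured compound carries 4-methoxyphenyl, however, so this particular group remains untested in this assay. On the evidence of these flat steps, no change beyond the scatter is expected, and the estimated step is no change at the digits printed from compound 1 to compound 4 (within the scatter). Compound 4 is expected to give about 12000 nM, with an estimated range from 6000 nM to 23000 nM.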

Compound 4, half-maximal inhibitory concentration: 18600 nM
Beside the measured number, compound 4's estimate is 1.6-fold (0.19 log units) below it; the measured number falls inside the stated range.
By their numbers in this assay, from the lowest: compounds 2, 1, 3 and 4 (each within the scatter of the next).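

With 4-methoxyphenyl on the double-bonded chain carbon bound to a double-bonded ring carbon, this assay still gives no step beyond the scatter: the exchange for 3-chlorophenyl is a 1.6-fold higher number from compound 1 to compound 4 (0.19 log units; within the scatter), and the exchange for 3-bromophenyl is a 1.6-fold higher number from compound 2 to compound 4 (0.20 log units; within the scatter). For the compounds shown here, the new compound also gives the first comparison of two methoxyphenyl groups at this place, and with a 1.6-fold higher number from compound 3 to compound 4 (0.19 log units; within the scatter), 2-methoxyphenyl and 4-methoxyphenyl cannot be told apart in this assay. All four groups at this place, two carrying a halogen and two a methoxy group, therefore lie within the scatter of one another, and no measurement at hand speaks to why this is so.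

The compounds shown leave open whether a group of a different kind at this place, such as a phenyl ring carrying an amine or a carboxylic acid, would give a number beyond the scatter of these four. They also leave open whether a change to the shared core itself, rather than to this group, would have any larger effect in this assay.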